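Swapping Difluoromethoxy for Chloro: Effect on Half-Life

The source may hold more compounds than are shown below. What is called first, only, known or untested is meant among the compounds shown, and "the series" means these compounds.

- compound 1 `CCc1nc(-c2ccc(Cl)cc2Cl)c(CC)nc1CC(CC)CC` gives 0.0417 h
- compound 2 `CCc1nc(-c2ccc(OC)nc2OC)c(CC)nc1NC(CC)CC` gives 0.0417 h
- compound 3 `CCc1nc(-c2ccc(OC(F)F)cc2Cl)c(OC)nc1NC(CC)CC` gives 0.283 h

In an in vitro ADME assay on microsomes (Rattus norvegicus) for metabolic stability (a higher number here means that the compound lasts longer, a lower number that the compound disappears faster), compound 3 gives 0.283 h, the highest of these three numbers and clearly beyond the usual scatter from both of the others. Compound 4 `CCc1nc(-c2ccc(Cl)cc2Cl)c(OC)nc1NC(CC)CC` has not been measured yet. It keeps compound 3 except for one change, chloro in place of difluoromethoxy on an aromatic carbon. Among the compounds with values here, no pair of measured compounds shows this change alone, so any forecast is uncertain. The nearest clue is compound 1, which also carries chloro in that place and gives 0.0417 h, but it differs from compound 4 elsewhere and is only a loose guide. A moderate fall in this assay therefore seems likely, and the expected step is a 2.2-fold lower number from compound 3 to compound 4 (0.34 log units; beyond the scatter). Compound 4 is estimated at 0.13 h, with an expected range from 0.05 h to 0.35 h.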

Compound 4, half-life: 0.183 h
Compound 4: middle estimate off by 1.4-fold (0.15 log units), on the low side, within the range that was stated.
By their numbers in this assay, from the lowest: compounds 1 and 2 (each within the scatter of the next); then compounds 4 and 3 (each within the scatter of the next).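

Within the data shown here, this pair gives the first clean reading of this change, since the earlier compounds differ from each other in more than one place. In this assay, chloro in place of difluoromethoxy on this aromatic carbon gives a 1.5-fold lower number from compound 3 to compound 4 (0.19 log units; within the scatter), so the two compounds cannot be told apart, even though one heavy atom replaces four and a hydrogen-bond acceptor is lost. Nothing measured here bears on why the half-life holds across this swap.

As far as these compounds go, this is a single pair, so it remains open whether the same holds when the rest of the molecule differs, for instance with the other substituents of compound 1 or compound 2. From the compounds shown here alone, it is also open whether a nitrile or an amine on the same aromatic carbon would leave the half-life just as unmoved.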